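This account rests on a few compounds, and the source may have more. Where it says the series, first, only, none or still open, it means among the compounds named here.

Three compounds share one core and differ only in the aryl group on the aromatic nitrogen. Compound 1 `COc1cc(-c2ncnn2-c2ccc(Cl)cc2Cl)cc(OC)c1OC` carries the 2,4-dichlorophenyl; in a functional assay on HeLa cells (Homo sapiens) for antiproliferative activity, read by MTT assay, with a stated time of 72 h (a lower number here means a stronger inhibitor, a higher number a weaker inhibitor), compound 1 gives only the limit > 10000 nM and no number. Compound 2 `COc1cc(-c2ncnn2-c2ccc(F)cc2)cc(OC)c1OC` carries the 4-fluorophenyl; in this assay compound 2 likewise reaches only the limit > 10000 nM. Compound 3 `COc1cc(-c2ncnn2-c2ccc(N)cc2)cc(OC)c1OC` carries the 4-aminophenyl; in this assay compound 3 again stops at the limit > 10000 nM. Compound 3 therefore stands nowhere readable within the series, since every value shown sits at the limit of > 10000 nM in this assay, at which 3 of the 3 values shown sit. The steps a step that the two limits leave unreadable from compound 1 to compound 2, a step that the two limits leave unreadable from compound 1 to compound 3 and a step that the two limits leave unreadable from compound 2 to compound 3 are all left unreadable by the limits. Compound 4 `COc1cc(-c2ncnn2-c2ccc(Cl)cc2)cc(OC)c1OC` differs from compound 3 by chloro in place of amino on an aromatic carbon. For the measured compounds named here, no measured step bears on this change with a readable size, and compound 1 and compound 2, the other two members, both sit at the limit. The step that the limit leaves unreadable from compound 3 to compound 4 is expected to be small, most likely leaving compound 4 at the limit as well. For compound 4 in this assay the estimate is 15000 nM, with a range from 5000 nM to 50000 nM.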

Compound 4, half-maximal inhibitory concentration: > 10000 nM
Compound 4: a limit, no number; the forecaster's own chance of this, stated with the estimate: 80%; the middle value lies beyond the limit too.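

No new step can be read between compound 4 and compound 1, compound 2 or compound 3 in this assay, since all four compounds stop at one limit: the limit of > 10000 nM in this assay, at which 4 of the 4 values shown sit.

The compounds shown leave open how far apart these four aryl groups on the shared core actually lie.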